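Pyridylmethyl position scan on the tetrahydroisoquinoline amine series

This account rests on a few compounds, and the source may have more. Where it says the series, first, only, none or still open, it means among the compounds named here.

Measured so far:
compound 1 `NCCCCN(C[C@H]1Cc2ccccc2CN1Cc1ccccn1)[C@H]1CCCc2cccnc21` — 56 nM
compound 2 `NCCCCN(C[C@H]1Cc2ccccc2CN1Cc1cccnc1)[C@H]1CCCc2cccnc21` — 350 nM

In a functional assay on Chem-1 cells for antagonist activity at C-X-C chemokine receptor type 4 (Homo sapiens), read by FLIPR and calcium flux, with a stated time of 10 min (a higher number here means a weaker inhibitor, a lower number a stronger inhibitor), compound 2 gives 350 nM, the higher of the two numbers recorded. Going by the values given here, the only measured step, a 6.3-fold higher number from compound 1 to compound 2 (0.80 log units; beyond the scatter), arises from pyridin-3-yl in place of pyridin-2-yl on a saturated chain carbon bound to an amine nitrogen in a ring.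

Compound 3 `NCCCCN(C[C@H]1Cc2ccccc2CN1Cc1ccncc1)[C@H]1CCCc2cccnc21` is not yet measured. Its difference from compound 2 is pyridin-4-yl in place of pyridin-3-yl on a saturated chain carbon bound to an amine nitrogen in a ring. Among the compounds with values here, no measured pair covers pyridin-3-yl against pyridin-4-yl, so the step from compound 1 to compound 2 bears on it only loosely: it shows that moving the ring nitrogen can shift this assay beyond the scatter, but gives no direction for this particular move. The working expectation is a step within the scatter, a 1.4-fold higher number from compound 2 to compound 3 (0.15 log units; within the scatter), with room for a further loss. Compound 3 is therefore estimated at 500 nM in this assay, expected between 150 nM and 2000 nM.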

Compound 3, half-maximal inhibitory concentration: 660 nM
Beside the measured number, compound 3's estimate is 1.3-fold (0.12 log units) below it; the measured number falls inside the stated range.
By their numbers in this assay, from the lowest: compound 1; then compounds 2 and 3 (each within the scatter of the next).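

In this assay the move to pyridin-4-yl gives a 1.9-fold higher number from compound 2 to compound 3 (0.28 log units; within the scatter), so these two isomers cannot be ordered on this evidence. Set against pyridin-2-yl, the same group gives a 12-fold higher number from compound 1 to compound 3 (1.07 log units; beyond the scatter), which, with the earlier step to pyridin-3-yl, makes compound 1 the strongest of the three isomers, with both alternatives separated from it beyond the scatter. On a saturated chain carbon bound to an amine nitrogen in a ring, pyridin-2-yl therefore stands apart, while no data offered here give a reason for the difference.

Open, on these data alone, is whether any ring nitrogen is needed at all, since a phenyl ring in this place would test that directly. Also open, as far as these compounds go, is whether a methyl or an amine added to the pyridin-2-yl ring would hold or improve the number of compound 1.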